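A nitro group added to compound 1

The source may report more compounds than this note shows. Statements on the series, on what has been measured and on what is new or still open speak of the compounds shown alone.

compound 1 `COC1=CC(=O)c2c(c(COc3ccccc3)c(C)n2C)C1=O`: 1390 nM
compound 2 `COC1=CC(=O)c2c(c(COc3cccc([N+](=O)[O-])c3)c(C)n2C)C1=O`: 352 nM

In a functional assay on MIA PaCa-2 cells (Homo sapiens) for cytotoxicity, read by MTT assay, with a stated time of 4 h (a higher number here means a weaker inhibitor, a lower number a stronger inhibitor), compound 1 gives the higher of the two numbers (1390 nM), which makes it the weaker inhibitor of this pair. Compound 3 `COC1=CC(=O)c2c(c(COc3ccccc3[N+](=O)[O-])c(C)n2C)C1=O` has not yet been measured. It is compound 1 with a single change: nitro in place of hydrogen on an aromatic carbon. Going by the values given here, only one measured step bears on this change: a 3.9-fold lower number from compound 1 to compound 2 (0.60 log units; beyond the scatter). There too a nitro group replaced a hydrogen on an aromatic carbon, though at a different place on the ring. That step is modest but beyond the scatter. Among the compounds with values here, with no measurement yet at the new place, a step in the same direction, perhaps somewhat smaller, is expected in this assay. The estimate means a 2.8-fold lower number from compound 1 to compound 3 (0.44 log units; beyond the scatter). For compound 3 the expected value is 500 nM, with an estimated range from 150 nM to 1500 nM.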

Compound 3, half-maximal inhibitory concentration: 345 nM
Beside the measured number, compound 3's estimate is 1.4-fold (0.16 log units) above it, within the range that was stated.
By their numbers in this assay, from the lowest: compounds 3 and 2 (each within the scatter of the next); then compound 1.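

In this assay, a nitro group ortho to a large group also lowers the number, with a 4.0-fold lower number from compound 1 to compound 3 (0.61 log units; beyond the scatter) as a modest step beyond the scatter. Compound 2 carries the same group at a different place on the ring, yet its number and that of compound 3 lie within the scatter of each other, so these two places cannot be told apart in this assay. Nothing measured here explains why the nitro group has this effect at either place.

The compounds shown leave open whether the lower number belongs to the nitro group itself or would also appear with another group at this place, such as an amine or a carboxylic acid. They also leave open how a longer chain at this place would compare with the nitro group.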